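The source may report more compounds than this note shows. Statements on the series, on what has been measured and on what is new or still open speak of the compounds shown alone.

Compound 1 `C=CS(=O)(=O)N1CCN(c2ccn3ncc(-c4ccccc4)c3n2)CC1`: 19500 nM
Compound 2 `C=CS(=O)(=O)N1CCN(c2ncnc3ccc(-c4ccccc4)cc23)CC1`: 23400 nM
Compound 3 `C=CS(=O)(=O)N1CCN(c2ncnc3sc(-c4ccc(OC)cc4)cc23)CC1`: 28400 nM

All three values come from a functional assay on MDA-MB-436 cells (Homo sapiens) for antiproliferative activity, read by MTT assay, with a stated time of 48 h; a higher number here means a weaker inhibitor, a lower number a stronger inhibitor. Compound 3, at 28400 nM, lies within the scatter of both compound 1 and compound 2, so the three cannot be ranked.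

Compound 4 `C=CS(=O)(=O)N1CCN(c2ncnc3sc(-c4cc(Br)cnc4F)cc23)CC1` keeps the core of compound 3 and carries 5-bromo-2-fluoropyridin-3-yl in place of 4-methoxyphenyl, on an aromatic carbon next to the ring sulfur: 5-bromo-2-fluoropyridin-3-yl in place of 4-methoxyphenyl on an aromatic carbon.

Within the data shown here, no measured pair isolates this change, so the only guide is how closely the three values sit. No step beyond the scatter is expected, in either direction. The estimated step, a 1.4-fold lower number from compound 3 to compound 4 (0.15 log units; within the scatter), reflects this. Compound 4 is expected at 20000 nM, with an estimated range of 8000 nM to 45000 nM.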

Compound 4, half-maximal inhibitory concentration: 28400 nM
For compound 4 the middle estimate is 1.4-fold (0.15 log units) below the measured one; the range from low to high includes it.
By their numbers in this assay, from the lowest: compounds 1, 2, 3 and 4 (each within the scatter of the next).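

Among these compounds, exchanging 4-methoxyphenyl for 5-bromo-2-fluoropyridin-3-yl on the aromatic carbon next to the ring sulfur gives no change at the digits printed from compound 3 to compound 4 (within the scatter) in this assay, the first one-place comparison. This position therefore accepts both aromatic rings, carbon-only and with 1 hetero atom, without a step beyond the scatter. No measurement available here explains why the two groups read alike.

As far as these compounds go, whether an amine, a carboxylic acid or a longer chain at this position would move the value beyond the scatter remains open.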